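A few compounds are considered here, and "the series" means these few. Any claim that something is new, unique, unknown or untested is made for them only; others in the source may bear on it.

Measured so far in a physicochemical assay for lipophilicity, at pH 7.4 (on this read-out lower numbers stand for lower lipophilicity and higher numbers for higher lipophilicity), are three compounds:
- compound 1 `CCc1ccc(N(CC(C)C)S(=O)(=O)c2ccc3c(c2)C(C)CC(C2CCOCC2)O3)cc1` with 5.71
- compound 2 `CC(C)CN(c1ccc(F)cc1)S(=O)(=O)c1ccc2c(c1)C(O)CC(C1CCOCC1)O2` with 3.39
- compound 3 `CCc1ccc(N(CC(C)C)S(=O)(=O)c2ccc3c(c2)C(C)(O)CC(C2CCOCC2)O3)cc1` with 4.19

Compound 1 stands highest of these three, with compound 3 nearest to it and compound 2 furthest below. Compound 4 `CCc1ccc(N(CC(C)C)S(=O)(=O)c2ccc3c(c2)C(OC2CCCCC2)CC(C2CCOCC2)O3)cc1` has not yet been measured. It comes from compound 1 through a single change, cyclohexyloxy in place of methyl on a saturated ring carbon and nothing else.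

For the measured compounds named here, only one measured step bears on this change. The step of a number 1.52 log units lower from compound 1 to compound 3 (beyond the scatter) is large and lies beyond the scatter, and it puts hydroxy in place of hydrogen on a saturated ring carbon. Compound 2 differs from compound 1 in more than one place, so it offers no clean comparison. Going by the values given here, no measured step brings in a group like cyclohexyloxy, which is mostly carbon, so the fall seen for compound 3 is a poor guide here and the estimate remains uncertain. In this assay a moderate rise is expected, with a number 0.69 log units higher from compound 1 to compound 4 (beyond the scatter) as the estimated step. For compound 4 the estimated value is 6.4 with an expected range from 5.7 to 7.1 for now.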

Compound 4, distribution coefficient: 6.28
Compound 4: the middle estimate sits 0.12 log units above what was measured; measured number inside the range.
By their numbers in this assay, from the lowest: compound 2; then compound 3; then compound 1; then compound 4.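

At this saturated ring carbon, two ring bonds from the ring atom that bears the oxan-4-yl group, this assay can move in either direction: cyclohexyloxy in place of methyl gives a number 0.57 log units higher from compound 1 to compound 4 (beyond the scatter), whereas hydroxy in place of hydrogen on the same carbon gives a number 1.52 log units lower from compound 1 to compound 3 (beyond the scatter). An oxygen attached to this carbon therefore does not settle the direction of the step on its own, since both entering groups carry one and the two steps have opposite signs, although hydroxy leaves the methyl in place and cyclohexyloxy replaces it. Nothing measured here explains why the number rises with cyclohexyloxy.

On these data alone, with only these two changes at this carbon, the contributions of the carbon ring and of the oxygen that links it cannot be separated, and it remains unknown how the step would change with the size of the entering group. A methoxy group in place of methyl, a cyclohexyl ring attached directly to this carbon, or an amine at the same place would each test a different part of that question.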